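Losing the Carboxy Group: Compound 3 to Compound 4

A few compounds are considered here, and "the series" means these few. Any claim that something is new, unique, unknown or untested is made for them only; others in the source may bear on it.

Measured in a physicochemical assay for solubility, in phosphate buffer, with a stated time of 18 h; a lower number here means a less soluble compound, a higher number a more soluble compound:
Compound 1 `CC(C)(C)c1nc(CCCCCC#N)c2c(N)c(C#N)c(N)nc2n1`: 6000 nM
Compound 2 `CC(C)(C)c1nc(-c2cccs2)c2c(N)c(C#N)c(N)nc2n1`: 56000 nM
Compound 3 `CC(C)(C)c1nc(-c2ccc(C(=O)O)s2)c2c(N)c(C#N)c(N)nc2n1`: > 1000000 nM

Compound 3 stands at > 1000000 nM, which is a limit of this assay and not a number. Its steps from the other two compounds put it highest of the three. In compound 4 `Cc1c[nH]c(-c2nc(C(C)(C)C)nc3nc(N)c(C#N)c(N)c23)n1`, 4-methyl-1H-imidazol-2-yl takes the place of 5-carboxythiophen-2-yl on an aromatic carbon (4-methyl-1H-imidazol-2-yl in place of 5-carboxythiophen-2-yl on an aromatic carbon).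

Among the measured compounds shown here, three measured steps bear on this change. Carboxy in place of hydrogen gave a large step, an at least 17-fold higher number from compound 2 to compound 3 (1.25 log units; beyond the scatter). Thiophen-2-yl in place of 5-cyanopentyl gave a modest one, a 9.3-fold higher number from compound 1 to compound 2 (0.97 log units; beyond the scatter), and 5-carboxythiophen-2-yl in its place a large one, an at least 160-fold higher number from compound 1 to compound 3 (2.22 log units; beyond the scatter). Compound 4 carries no carboxy, so a modest to large step to a lower number is expected, with compound 2 at 56000 nM as the nearest reference. The expected change is an at least 11-fold lower number from compound 3 to compound 4 (1.04 log units; beyond the scatter). For compound 4 the estimated value is 90000 nM, with an expected range of 25000 nM to 350000 nM.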

Compound 4, solubility: 5000 nM
Compound 4: the middle estimate sits 18-fold (1.26 log units) above what was measured, outside the stated range (below it).
By their numbers in this assay, from the lowest: compounds 4 and 1 (each within the scatter of the next); then compound 2. At a limit, above all of these: compound 3.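

In this assay, a five-membered aromatic ring at this position did not by itself keep the number high: 4-methyl-1H-imidazol-2-yl in place of thiophen-2-yl gave an 11-fold lower number from compound 2 to compound 4 (1.05 log units; beyond the scatter), and in place of 5-cyanopentyl it gave a 1.2-fold lower number from compound 1 to compound 4 (0.08 log units; within the scatter). Against 5-carboxythiophen-2-yl, the same group gave an at least 200-fold lower number from compound 3 to compound 4 (2.30 log units; beyond the scatter). That step rests on the value of compound 3, which is a limit and not a number: the limit of > 1000000 nM in this assay, at which 1 of the 4 values shown sits.

The compounds shown leave open whether the step from compound 2 belongs to the imidazole ring or to its methyl, which a 1H-imidazol-2-yl group without the methyl would separate. They also leave open whether a carboxylic acid on the imidazole ring would lift the number in this assay as it did on the thiophene.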